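A Ring Swap on Compound 1

A few compounds are considered here, and "the series" means these few. Any claim that something is new, unique, unknown or untested is made for them only; others in the source may bear on it.

In a functional assay on A549 cells (Homo sapiens) for antiproliferative activity, read by MTT assay, with a stated time of 72 h (a higher number here means a weaker inhibitor, a lower number a stronger inhibitor), compound 1 (`C/C=C/C(=O)Nc1cccc(Oc2nc(Nc3cccc(OC)c3)nc3c2CSCC3)c1`) gives 21100 nM as its half-maximal inhibitory concentration. Two close relatives provide the comparison: compound 2 (`CCC/C=C/C(=O)Nc1cccc(Oc2nc(Nc3cccc(OC)c3)nc3c2CSCC3)c1`) gives 11800 nM and compound 3 (`COc1cccc(Nc2nc3c(c(Oc4cccc(NC(=O)/C=C/C(C)C)c4)n2)CSCC3)c1`) gives 25300 nM. Compound 1 lies within the scatter of both, even though those two relatives differ modestly from each other (a 2.1-fold higher number from compound 2 to compound 3 (0.33 log units; beyond the scatter)).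

Compound 4 (`C/C=C/C(=O)Nc1cccc(Oc2nc(Nc3ccc(OC)nc3)nc3c2CSCC3)c1`) keeps the chain of compound 1 and changes a different part of the molecule: 6-methoxypyridin-3-yl in place of 3-methoxyphenyl on a nitrogen on an aromatic ring. Here, 6-methoxypyridin-3-yl stands in place of 3-methoxyphenyl on a nitrogen on an aromatic ring. Among the measured compounds shown here, none of the measured steps touches this group. The two steps that start from compound 1 alter only the chain (a 1.8-fold lower number from compound 1 to compound 2 (0.25 log units; within the scatter); a 1.2-fold higher number from compound 1 to compound 3 (0.08 log units; within the scatter)), so they give no direct guide to the size or direction of this swap. With no evidence for a direction, no shift beyond the scatter is expected, and the estimated change is small (a 1.1-fold lower number from compound 1 to compound 4 (0.02 log units; within the scatter)). For compound 4 the expected value is 20000 nM, within an estimated range of 8000 nM to 45000 nM.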

Compound 4, half-maximal inhibitory concentration: 8040 nM
Estimate against measurement, compound 4: 2.5-fold (0.40 log units) above; the range from low to high includes it.
By their numbers in this assay, from the lowest: compounds 4, 2, 1 and 3 (each within the scatter of the next, the first and the last beyond it).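

Swapping 3-methoxyphenyl for 6-methoxypyridin-3-yl on the nitrogen gives, in this assay, a 2.6-fold lower number from compound 1 to compound 4 (0.42 log units; beyond the scatter), so this group can move the number beyond the scatter, though only modestly. Among the compounds shown here, the two chain changes made on compound 1 stay within the scatter, at a 1.8-fold lower number from compound 1 to compound 2 (0.25 log units; within the scatter) and a 1.2-fold higher number from compound 1 to compound 3 (0.08 log units; within the scatter), which makes this the only step from compound 1 here that clearly registers. The entering ring holds a hetero atom where the leaving ring is carbon only, but no measurement here explains why the number falls.

Going by these compounds, whether the same swap would lower the number when paired with the chains of compound 2 or compound 3 remains open. So does the effect of replacing the methoxy on the pyridine ring with an amine or a fluorine.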